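The source may hold more compounds than are shown below. What is called first, only, known or untested is meant among the compounds shown, and "the series" means these compounds.

Measured in a functional assay on MDA-MB-435 cells (Homo sapiens) for antiproliferative activity; on this read-out lower numbers stand for stronger inhibition of growth and higher numbers for weaker inhibition of growth:
- compound 1 `Oc1cc(-c2ccc3ccccc3c2)nc2ncccc12`: 1780 nM
- compound 2 `Cc1ccnc2nc(-c3cccc4ccccc34)cc(O)c12`: < 10 nM (a limit)
- compound 3 `Cc1cc(C)c2c(O)cc(-c3cccc(F)c3)nc2n1`: < 10 nM (a limit)

For the measured compounds named here, compound 1 is the only compound with an actual number; the others sit at the limit of < 10 nM in this assay, at which 2 of the 3 values shown sit.

Compound 4 `Cc1ccnc2nc(-c3ccc4ccccc4c3)cc(O)c12` differs from compound 1 by methyl in place of hydrogen on an aromatic carbon, a methyl in place of hydrogen on an aromatic carbon.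

Going by the values given here, no measured pair isolates this change. Compound 2 carries the same methyl with a different aryl group and reports < 10 nM, a limit. Compound 3 also carries that methyl and reports < 10 nM, a limit.

On those two limits, a large step toward stronger inhibition of growth is expected, estimated as a 12-fold lower number from compound 1 to compound 4 (1.07 log units; beyond the scatter). Compound 4 is estimated at 150 nM, with an expected range of 25 nM to 900 nM.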

Compound 4, concentration for 50% growth inhibition: 204 nM
For compound 4 the middle estimate is 1.4-fold (0.13 log units) below the measured one, and the stated range covers the measured number.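

In this assay the methyl in place of hydrogen on an aromatic carbon, opposite the ring nitrogen, now has a measured size with the aryl group unchanged: an 8.7-fold lower number from compound 1 to compound 4 (0.94 log units; beyond the scatter) is a step beyond the scatter. Compound 4 gives a real number, so this methyl alone does not bring this aryl group to the limit reported for compound 2 and compound 3: the limit of < 10 nM in this assay, at which 2 of the 4 values shown sit.

As far as these compounds go, whether an ethyl, a methoxy or an amine on this carbon would match the methyl remains open. The same step cannot be read for the aryl groups of compound 2 and compound 3, as neither compound has a partner without the methyl.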